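A few compounds are considered here, and "the series" means these few. Any claim that something is new, unique, unknown or untested is made for them only; others in the source may bear on it.

Compound 1 `C=C1C(=O)[C@]23C[C@@]1(O)CC[C@H]2c1ccc(O)c(C)c1[C@@H]3Cn1cc(-c2ccc(C)cc2)nn1` is the reference point of this small set. In a functional assay on SW480 cells (Homo sapiens) for cytotoxicity, read by MTT assay, with a stated time of 4 days (on this read-out higher numbers stand for weaker inhibition and lower numbers for stronger inhibition), compound 1 gives 330 nM, the lower of the two numbers recorded, and its nearest neighbour is compound 2 `C=C1C(=O)[C@]23C[C@@]1(O)CC[C@H]2c1ccc(OS(=O)(=O)c2ccc(C)cc2)c(C)c1[C@@H]3Cn1cc(-c2ccc(C)cc2)nn1`, which in this assay gives 1460 nM. The step of a 4.4-fold higher number from compound 1 to compound 2 (0.65 log units; beyond the scatter) puts (4-methylphenyl)sulfonyl in place of hydrogen on an oxygen on an aromatic ring. Compound 3 `C=C1C[C@]23C[C@@]1(O)CC[C@H]2c1ccc(O)c(C)c1[C@@H]3Cn1cc(-c2ccccc2)nn1` reaches in this assay only a limit of the assay, > 20000 nM, the one noted as the limit of > 20000 nM in this assay, at which 1 of the 3 values shown sits. Among the measured compounds shown here, compound 3 differs from compound 1 in more than one place, so no single step joins them.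

Compound 4 `C=C1C(=O)[C@]23C[C@@]1(O)CC[C@H]2c1ccc(O)c(C)c1[C@@H]3Cn1cc(-c2ccc(Cl)cc2)nn1` differs from compound 1 by chloro in place of methyl on an aromatic carbon. For the measured compounds named here, no measured step touches this part of the structure: the only measured step concerns the oxygen on the aromatic ring, while the change here sits on the 4-methylphenyl group. With nothing to point either way, one expects the step of a 1.1-fold lower number from compound 1 to compound 4 (0.04 log units; within the scatter) to stay within the scatter. Compound 4 is therefore estimated to give 300 nM in this assay, with a range from 120 nM to 800 nM.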

Compound 4, half-maximal inhibitory concentration: 280 nM
Beside the measured number, compound 4's estimate is 1.1-fold (0.03 log units) above it; low and high end bracket the measured number.
By their numbers in this assay, from the lowest: compounds 4 and 1 (each within the scatter of the next); then compound 2. At a limit, above all of these: compound 3.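

In this assay, among the compounds shown here, the step of a 1.2-fold lower number from compound 1 to compound 4 (0.07 log units; within the scatter) gives the first reading at the far aromatic ring, whereas the only earlier step concerned the oxygen on the other aromatic ring. Chloro and methyl, on an aromatic carbon para to a large group, cannot be told apart by this read-out, so the 4-chlorophenyl and 4-methylphenyl groups serve equally well here. Nothing shown explains why the two groups match.

As far as these compounds go, two groups are a narrow sample of this place, and it stays open whether an amine, a carboxylic acid or a longer chain there would keep the number within the scatter. From the compounds shown here alone, compound 3 carries no group at this place, but it also differs elsewhere from compound 1, so the effect of hydrogen here on the core of compound 1 remains open too.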